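From Hydroxy to Methylsulfonyl on Compound 2

This account rests on a few compounds, and the source may have more. Where it says the series, first, only, none or still open, it means among the compounds named here.

Compound 1 (`N#Cc1ccc(-c2cncc(-c3cc4ccc(O)cc4[nH]3)n2)cc1`) reads 25000 nM in an ADME assay on cells (Fibroblast, Homo sapiens) for cytotoxicity, with a stated time of 48 h (a higher number here means a weaker inhibitor, a lower number a stronger inhibitor), and compound 2 (`Oc1ccc(-c2cncc(-c3cc4cc(O)ccc4[nH]3)n2)cc1`) reads 15000 nM there, so the two stand within the usual scatter of each other. Compound 3 (`CS(=O)(=O)c1ccc(-c2cncc(-c3cc4cc(O)ccc4[nH]3)n2)cc1`) carries methylsulfonyl in place of hydroxy on an aromatic carbon, para to a large group (methylsulfonyl in place of hydroxy on an aromatic carbon). Within the data shown here, no measured pair differs in one place only, so no measured step guides this change. The expectation leans on compound 1 at 25000 nM, which has nitrile instead of hydroxy at that place. The expected 1.3-fold higher number from compound 2 to compound 3 (0.12 log units; within the scatter) is small, towards a higher number, and within the scatter. The estimated value for compound 3 is 20000 nM (expected range 8000 nM to 50000 nM).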

Compound 3, half-maximal inhibitory concentration: 25000 nM
Compound 3: the middle estimate sits 1.3-fold (0.10 log units) below what was measured; measured number inside the range.
By their numbers in this assay, from the lowest: compounds 2, 1 and 3 (each within the scatter of the next).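

In this assay, among these compounds, methylsulfonyl in place of hydroxy on this aromatic carbon gives a 1.7-fold higher number from compound 2 to compound 3 (0.22 log units; within the scatter) as the first direct reading at this position. The exchange removes the hydrogen-bond donor of hydroxy and adds heavy atoms, yet the two compounds remain within the scatter of each other. No available measurement offers an explanation for this reading. The compounds shown leave open whether an amine or a carboxylic acid at this place would shift the number beyond the scatter.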